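Phenylsulfanyl in place of pyridinylethyl on the shared core

This account rests on a few compounds, and the source may have more. Where it says the series, first, only, none or still open, it means among the compounds named here.

Measured in a functional assay on HEK293 cells for positive allosteric modulation of metabotropic glutamate receptor 5 (Homo sapiens), read by FLIPR and calcium flux; on this read-out lower numbers stand for an effect already at smaller amounts and higher numbers for an effect only at larger amounts of compound:
compound 1, `O=C(COCc1cscn1)N1CCN(c2ccc(Cl)cc2Cl)CC1`, gives 290 nM;
compound 2, `O=C(COCc1cncs1)N1CCN(c2ccc(Cl)cc2Cl)CC1`, gives 1280 nM;
compound 3, `O=C(CCCc1ccncc1)N1CCN(c2ccc(Cl)cc2Cl)CC1`, gives 5300 nM.

Compound 3 stands highest of the three numbers in this assay; its nearest neighbour is compound 2, the furthest compound 1, and both gaps lie beyond the scatter. Compound 4, `O=C(CSc1ccccc1)N1CCN(c2ccc(Cl)cc2Cl)CC1`, differs from compound 3 by one change: phenylsulfanyl in place of 2-(pyridin-4-yl)ethyl on a saturated chain carbon bound to a carbonyl carbon. For the measured compounds named here, two measured steps bear on this. Both an 18-fold higher number from compound 1 to compound 3 (1.26 log units; beyond the scatter) and a 4.1-fold higher number from compound 2 to compound 3 (0.62 log units; beyond the scatter) describe the reverse direction: a heteroaryl group held through an oxygen on a saturated carbon was exchanged for the 2-(pyridin-4-yl)ethyl chain, and the number rose each time, once largely and once modestly. Compound 4 again carries an aromatic ring joined through a hetero atom, sulfur, directly on the chain carbon next to the carbonyl, so a drop in the number beyond the scatter is expected in this assay, most likely back toward the range of compound 1 and compound 2. Compound 4 is therefore estimated at 500 nM, with a range from 150 nM to 2000 nM, which means an expected step of an 11-fold lower number from compound 3 to compound 4 (1.03 log units; beyond the scatter).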

Compound 4, half-maximal effective concentration: > 25000 nM
Compound 4 gave a limit, no number; the forecaster's own chance of this, stated with the estimate: 5%; middle value at least 50-fold (1.69 log units) away from the limit.
By their numbers in this assay, from the lowest: compound 1; then compound 2; then compound 3. At a limit, above all of these: compound 4.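

The reading for compound 4 in this assay is a limit of the assay and not a number: the limit of > 25000 nM in this assay, at which 1 of the 4 values shown sits. Even so, the step to it can be read, an at least 4.7-fold higher number from compound 3 to compound 4 (0.67 log units; beyond the scatter), so an aromatic ring held through sulfur on a saturated chain carbon bound to a carbonyl carbon did not restore the lower numbers of the thiazole compounds. For the compounds shown here, the comparisons with those two, an at least 19-fold higher number from compound 2 to compound 4 (1.29 log units; beyond the scatter) and an at least 86-fold higher number from compound 1 to compound 4 (1.93 log units; beyond the scatter), show that at this place an aromatic ring joined through a hetero atom is not enough in itself, which the earlier compounds, all of which gave numbers, did not show.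

On these data alone, whether the rise belongs to the sulfur link or to the carbon-only ring stays open. A benzyloxy or a pyridin-4-ylsulfanyl group at this place would separate the two.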